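The compounds below may be only part of what the source reports. "The series", "measured", "known", "first", "only" and "open" are said of these compounds alone.

Measured in an ADME assay on microsomes from liver (Mus musculus) for metabolic stability, read by LC-MS, using NADPH, with stated times of 10 min and 30 min, tested at 1 uM; on this read-out higher numbers stand for fast clearance and lower numbers for slow clearance:

Compound 1 `COC(=O)C1=C(CN2CCOCC2=O)NC(c2nccs2)=NC1(C)c1ccc(F)cc1`: 80 mL/min/kg
Compound 2 `COC(=O)C1=C(CN2CCC(O)C2)NC(c2nccs2)=NC1(C)c1ccc(F)cc1`: 83 mL/min/kg

Only these two compounds have been measured, and they cannot be told apart on this read-out. Compound 2, at 83 mL/min/kg, stands level with compound 1, and the gap is a 1.0-fold higher number from compound 1 to compound 2 (0.02 log units; within the scatter). Compound 3 `COC(=O)C1=C(CN2CCCS2(=O)=O)NC(c2nccs2)=NC1(C)c1ccc(F)cc1` keeps the shared core of compound 2 and differs in one place: a group of 7 heavy atoms (3 carbon, 1 nitrogen, 2 oxygen, 1 sulfur; one five-membered non-aromatic ring with 2 hetero atoms) in place of a group of 6 heavy atoms (4 carbon, 1 nitrogen, 1 oxygen; one five-membered non-aromatic ring with 1 hetero atom), on a saturated chain carbon bound to a double-bonded ring carbon.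

Going by the values given here, one measured step bears on this change. It also exchanges one ring group for another at the same place on the chain, and it stayed within the scatter: a 1.0-fold higher number from compound 1 to compound 2 (0.02 log units; within the scatter). Among the compounds with values here, no measured compound carries the group that enters in compound 3, so this single step is weak evidence, and it gives no direction. Nothing beyond the scatter is therefore expected in this assay. The expected step, which lies within the scatter, is a 1.1-fold lower number from compound 2 to compound 3 (0.04 log units; within the scatter). The estimate for compound 3 is 75 mL/min/kg, with an expected range of 45 mL/min/kg to 105 mL/min/kg.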

Compound 3, clearance: 79 mL/min/kg
Compound 3: middle estimate off by 1.1-fold (0.02 log units), on the low side; the measured number falls inside the stated range.
By their numbers in this assay, from the lowest: compounds 3, 1 and 2 (each within the scatter of the next).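

In this assay, a third ring group on the saturated chain carbon bound to a double-bonded ring carbon gives a number level with the other two. The entering group, with its five-membered non-aromatic ring holding 2 hetero atoms, replaces 3-hydroxypyrrolidin-1-yl (a 1.1-fold lower number from compound 2 to compound 3 (0.02 log units; within the scatter)) and, read against the other neighbour, stands in place of 3-oxomorpholin-4-yl (a 1.0-fold lower number from compound 1 to compound 3 (0.01 log units; within the scatter)), so the three groups cannot be told apart here, even though the entering group has 0 hydrogen-bond donors against 1 in the group that leaves and carries 2 double bonds outside aromatic rings. No measurement in hand speaks to why these compounds stand level.

From the compounds shown here alone, all three compounds carry a ring group at this place, so it remains open whether an open-chain group, such as a dimethylamine or a carboxylic acid on a longer chain, would move the number beyond the scatter. Going by these compounds, it also remains open whether any change elsewhere on the shared core would separate compounds that this position leaves level.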